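Compound 1 Exchanges 4-Hydroxycyclohexyl for 3,4-Dinitrophenyl

The compounds below may be only part of what the source reports. "The series", "measured", "known", "first", "only" and "open" are said of these compounds alone.

Measured in a functional assay on RS4-11 cells (Homo sapiens) for inhibition, read by CCK-8 assay, with a stated time of 48 h; on this read-out higher numbers stand for weaker inhibition and lower numbers for stronger inhibition:
- compound 1 `O=C(NCCNS(=O)(=O)c1ccc(-c2ccccc2O[C@H]2CC[C@H](O)CC2)s1)Nc1cc(C(F)(F)F)cc(C(F)(F)F)c1`: 10100 nM
- compound 2 `COc1ccc(Oc2ccccc2-c2ccsc2S(=O)(=O)N2CCN(C(=O)Nc3ccc([N+](=O)[O-])cc3)CC2)cc1OC`: > 50000 nM (a limit of the assay)
- compound 3 `CC(C)c1ccc(Oc2ccc(O)c(O)c2)c(-c2ccsc2S(=O)(=O)NCCNC(=O)Nc2cc(Cl)cc(Cl)c2)c1`: 6400 nM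

In this assay, compound 1 lies within the usual scatter of compound 3, so the two cannot be ranked. Compound 2 gives only a limit, > 50000 nM.

Compound 4 `O=C(NCCNS(=O)(=O)c1ccc(-c2ccccc2Oc2ccc([N+](=O)[O-])c([N+](=O)[O-])c2)s1)Nc1cc(C(F)(F)F)cc(C(F)(F)F)c1` carries 3,4-dinitrophenyl in place of 4-hydroxycyclohexyl on an oxygen on an aromatic ring. No measured pair differs in only one place, so the size of this change has not been shown directly. With compound 1 at 10100 nM as the starting point, no step beyond the scatter is expected in this assay. The expected step is a 1.3-fold lower number from compound 1 to compound 4 (0.10 log units; within the scatter). For compound 4, the estimated value is 8000 nM, with an expected range of 2500 nM to 30000 nM.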

Compound 4, half-maximal inhibitory concentration: 2400 nM
The estimate for compound 4 lay 3.3-fold (0.52 log units) above the measured number; the measured number lies below the stated range.
By their numbers in this assay, from the lowest: compound 4; then compounds 3 and 1 (each within the scatter of the next). At a limit, above all of these: compound 2.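

In this assay, within the data shown here, 3,4-dinitrophenyl in place of 4-hydroxycyclohexyl on an oxygen on an aromatic ring gives a 4.2-fold lower number from compound 1 to compound 4 (0.62 log units; beyond the scatter), the first step read between compounds that differ in one place. It shows that the number responds to the group at this position, and that the non-aromatic ring with its hydroxyl is not required for a value of this size. Nothing measured here accounts for the step.

On these data alone, it remains open whether unsubstituted phenyl, a phenyl with a single nitro group, or one bearing an amine or a carboxylic acid would give a similar step. As far as these compounds go, whether the same exchange holds on other cores also remains open.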